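Isopropyl on a compound sitting at a limit

A few compounds are considered here, and "the series" means these few. Any claim that something is new, unique, unknown or untested is made for them only; others in the source may bear on it.

In a functional assay on HeLa cells (Homo sapiens) for inhibition, read by CCK-8 assay, with a stated time of 48 h (a lower number here means a stronger inhibitor, a higher number a weaker inhibitor), compound 1 (`O=S(=O)(NCCNC(=S)Nc1cccc(Cl)c1)c1ccc(-c2ccccc2OCc2cccc(O)c2)s1`) gives 10700 nM and compound 3 (`O=S(=O)(NCCNC(=S)Nc1ccc(Cl)cc1)c1ccc(-c2ccccc2OCc2ccccc2)s1`) gives 7000 nM as real numbers. Compound 2 (`O=C(NCCNS(=O)(=O)c1sccc1-c1ccccc1Oc1ccc(O)c(O)c1)Nc1cc(Cl)cc(Cl)c1`) reads > 50000 nM there, which is a limit and not a number. Its true position is therefore unknown, and it can only be said to lie at the weak end of the three values. Compound 4 (`CC(C)c1ccc(Oc2ccc(O)c(O)c2)c(-c2ccsc2S(=O)(=O)NCCNC(=O)Nc2cc(Cl)cc(Cl)c2)c1`) has isopropyl in place of hydrogen on an aromatic carbon and is otherwise unchanged. For the measured compounds named here, no measured pair shows what this change does in this assay so only a modest gain is expected. The estimated change is an at least 1.6-fold lower number from compound 2 to compound 4 (0.22 log units; that floor lies within the scatter) toward stronger inhibition, though a second limit would be unsurprising. For compound 4 the expected value is 30000 nM with an estimated range of 10000 nM to 70000 nM as its likely span.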

Compound 4, half-maximal inhibitory concentration: > 50000 nM
Compound 4 gave a limit, no number (the forecaster's own chance of this, stated with the estimate: 45%); middle value at least 1.6-fold (0.22 log units) from the limit.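

Compound 2 and compound 4 both read as limits rather than numbers, so the step between them cannot be read: the limit of > 50000 nM in this assay, at which 2 of the 4 values shown sit.

What isopropyl in place of hydrogen does to inhibition stays open in the compounds shown.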